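The compounds below may be only part of what the source reports. "The series", "measured", "known", "first", "only" and "open" are said of these compounds alone.

Measured compounds in a functional assay on MCF7 cells (Homo sapiens) for antiproliferative activity, read by MTT assay, with a stated time of 48 h; on this read-out higher numbers stand for weaker inhibition and lower numbers for stronger inhibition:
- compound 1 `CCn1c(C(=O)Nc2ccc(OC(F)(F)F)cc2)ccc1C(CC)(CC)c1ccc(OCCC(O)(CC)CC)c(C)c1` gives > 50000 nM, which is a limit of the assay rather than a number.
- compound 2 `CCC(C)C(CO)NC(=O)c1ccc(C(CC)(CC)c2ccc(OCCC(O)(CC)CC)c(C)c2)n1CC` gives 29100 nM.
- compound 3 `CCn1c(C(=O)N(C)CCO)ccc1C(CC)(CC)c1ccc(OCCC(O)(CC)CC)c(C)c1` gives 2870 nM.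

Compound 1 thus stands at the limit of > 50000 nM in this assay, at which 1 of the 3 values shown sits, and only a limit is known for it. Compound 4 `CCn1c(C(=O)NC(CO)CCO)ccc1C(CC)(CC)c1ccc(OCCC(O)(CC)CC)c(C)c1` is still to be measured in this assay. It differs from compound 1 in one place: 3-hydroxy-1-(hydroxymethyl)propyl in place of 4-(trifluoromethoxy)phenyl on an amide-type nitrogen. For the measured compounds named here, two measured steps bear on this change. The step of an at least 1.7-fold lower number from compound 1 to compound 2 (0.23 log units; that floor lies within the scatter) also puts a hydroxyalkyl group on the same amide-type nitrogen in place of the aryl group, and the step of an at least 17-fold lower number from compound 1 to compound 3 (1.24 log units; beyond the scatter) exchanges the whole amino part on the carbonyl carbon for a smaller hydroxyalkyl one. Between those two, a 10-fold lower number from compound 2 to compound 3 (1.01 log units; beyond the scatter). The change leading to compound 4 resembles the step to compound 2 more closely than the step to compound 3, while bringing a second hydroxyl into the chain. A lowering of the number is therefore expected, modest in size and with a fair chance that the assay again reports only its limit. Compound 4 is estimated at 15000 nM, expected to fall between 4000 nM and 50000 nM. The expected step is then an at least 3.3-fold lower number from compound 1 to compound 4 (0.52 log units; beyond the scatter).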

Compound 4, half-maximal inhibitory concentration: 31400 nM
Estimate against measurement, compound 4: 2.1-fold (0.32 log units) below; low and high end bracket the measured number.
By their numbers in this assay, from the lowest: compound 3; then compounds 2 and 4 (each within the scatter of the next). At a limit, above all of these: compound 1.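

In this assay, 3-hydroxy-1-(hydroxymethyl)propyl in place of 4-(trifluoromethoxy)phenyl on the amide-type nitrogen brings an at least 1.5-fold lower number from compound 1 to compound 4 (0.20 log units; that floor lies within the scatter) and, because compound 1 has only a limit and not a number, this floor does not fix the true size of the step: the limit of > 50000 nM in this assay, at which 1 of the 4 values shown sits. For the compounds shown here, a second hydroxyl-bearing chain on this nitrogen now stands beside the one in compound 2, and 2-hydroxyethyl in place of sec-butyl gives a 1.1-fold higher number from compound 2 to compound 4 (0.03 log units; within the scatter) so that the two compounds cannot be told apart in this read-out. The gap to compound 3 stays, with an 11-fold higher number from compound 3 to compound 4 (1.04 log units; beyond the scatter) showing that a hydroxyl in the chain is not enough on its own, since compounds 2, 3 and 4 all carry one and only compound 3 reaches the low numbers.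

The compounds shown leave open which part of the (2-hydroxyethyl)(methyl)amino group of compound 3 goes with its lower number, the methyl on the nitrogen or the short hydroxyethyl chain. A (2-hydroxyethyl)amino group or a dimethylamino group on the carbonyl carbon would pull those two parts apart.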